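A longer chain on compound 3

This account rests on a few compounds, and the source may have more. Where it says the series, first, only, none or still open, it means among the compounds named here.

Within the data shown here, in a functional assay on HeLa cells (Homo sapiens) for cytotoxicity, read by MTT assay, with a stated time of 24 h (a lower number here means a stronger inhibitor, a higher number a weaker inhibitor), compound 3 (`CCCCCC(=O)Nc1nnc(S[C@@H]2O[C@H](CO)[C@H](O)[C@H](O)[C@H]2O)s1`) gives 45600 nM, the highest of the three numbers so far. Compound 1 (`CCCCCCCCCCCCCCCCCC(=O)Nc1nnc(S[C@@H]2O[C@H](CO)[C@H](O)[C@H](O)[C@H]2O)s1`) gives 11200 nM and compound 2 (`CCCCCCCC/C=C\CCCCCCCC(=O)Nc1nnc(S[C@@H]2O[C@H](CO)[C@H](O)[C@H](O)[C@H]2O)s1`) gives 8800 nM. Compound 4 (`CCCCCCCCCCCCCCCC(=O)Nc1nnc(S[C@@H]2O[C@H](CO)[C@H](O)[C@H](O)[C@H]2O)s1`) differs from compound 3 by decyl in place of hydrogen on a saturated chain carbon, five bonds along the chain from a carbonyl carbon. Among the measured compounds shown here, the nearest precedent is a 4.1-fold higher number from compound 1 to compound 3 (0.61 log units; beyond the scatter), where hydrogen replaces dodecyl at that place. The step of a 5.2-fold higher number from compound 2 to compound 3 (0.71 log units; beyond the scatter) points the same way. Both are modest and beyond the scatter, so a modest step of similar size in the opposite direction is expected. The expected change is a 3.3-fold lower number from compound 3 to compound 4 (0.51 log units; beyond the scatter). For compound 4 the estimate is 14000 nM, within an expected range of 8000 nM to 25000 nM.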

Compound 4, half-maximal inhibitory concentration: 14200 nM
The estimate for compound 4 lay 1.0-fold (0.01 log units) below the measured number, and the stated range covers the measured number.
By their numbers in this assay, from the lowest: compounds 2, 1 and 4 (each within the scatter of the next); then compound 3.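

In this assay, decyl in place of hydrogen on a saturated chain carbon, five bonds along the chain from a carbonyl carbon, gives a 3.2-fold lower number from compound 3 to compound 4 (0.51 log units; beyond the scatter), a step beyond the scatter. The steps of a 1.6-fold higher number from compound 2 to compound 4 (0.21 log units; within the scatter) and a 1.3-fold higher number from compound 1 to compound 4 (0.10 log units; within the scatter) both lie within the scatter, so they set no order among these long-chain compounds. No measurement shown explains this result.

The compounds shown leave open how the number runs for chain lengths between those of compound 3 and compound 4. They also leave open whether a chain carrying an amine or a carboxylic acid would hold it.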